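From chloro to cyano at the assay limit

A few compounds are considered here, and "the series" means these few. Any claim that something is new, unique, unknown or untested is made for them only; others in the source may bear on it.

In a functional assay on HepG2 cells (Homo sapiens) for cytotoxicity, read by MTT assay, with a stated time of 72 h (on this read-out lower numbers stand for stronger inhibition and higher numbers for weaker inhibition), compound 1 (`CNC(=O)c1cc(Oc2ccc(C3=NNC(c4ccc(C#N)cc4)C3)cc2)ccn1`) gives a measured number (15000 nM). Compound 2 (`CNC(=O)c1cc(Oc2ccc(C3=NN(C(N)=S)C(c4cccc([N+](=O)[O-])c4)C3)cc2)ccn1`) gives only a limit of the assay (> 50000 nM). Compound 3 (`CNC(=O)c1cc(Oc2ccc(C3=NN(C(N)=S)C(c4ccc(Cl)cc4)C3)cc2)ccn1`) also gives only a limit of the assay (> 50000 nM). Compound 3 therefore has no number of its own and stands at the limit of > 50000 nM in this assay, at which 2 of the 3 values shown sit, with its true position unknown.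

The change to compound 4 (`CNC(=O)c1cc(Oc2ccc(C3=NN(C(N)=S)C(c4ccc(C#N)cc4)C3)cc2)ccn1`) is cyano in place of chloro on an aromatic carbon and reads as 4-chlorophenyl to 4-cyanophenyl, with cyano in place of chloro on an aromatic carbon.

For the measured compounds named here, the one measured step that touches this aryl group is a step that the two limits leave unreadable from compound 2 to compound 3 and it gives no size to carry over. Going by the values given here, compound 1 is the only compound with a number (15000 nM) and it carries the same 4-cyanophenyl group, so a measurable value for compound 4 cannot be ruled out. No direction can be read from the measured steps, and this assay is more likely than not to return a limit again. The expected change is small (a number no higher from compound 3 to compound 4 (the limit leaves the size open)). For compound 4 the estimated value is 50000 nM (expected range 15000 nM to 100000 nM).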

Compound 4, half-maximal inhibitory concentration: > 50000 nM
Compound 4: no number, only a limit; the forecaster's own chance of this, stated with the estimate: 60%; the middle value lies on the limit itself.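

In this assay, with cyano in place of chloro on the aromatic carbon, compound 4 still gives only a limit of the assay, > 50000 nM. For the compounds shown here, the 4-cyanophenyl group alone therefore does not secure a measurable value, and with that group held constant the one readable step is an at least 3.3-fold higher number from compound 1 to compound 4 (0.52 log units; beyond the scatter), which ties the loss to the change on the amine nitrogen in the ring. The steps linking compound 2, compound 3 and compound 4 cannot be read, so 3-nitrophenyl, 4-chlorophenyl and 4-cyanophenyl cannot be ordered, and the series remains largely at one limit: the limit of > 50000 nM in this assay, at which 3 of the 4 values shown sit.

Compound 1 is the only compound shown with a hydrogen on that nitrogen, so it remains open whether the hydrogen gives a measurable value with 4-chlorophenyl or 3-nitrophenyl as well. On these data alone, it also remains open whether an acetyl or a methyl group on that nitrogen would keep a measurable value or return the limit.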